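Swapping phenoxy for phenyl in a bile acid receptor series

This account rests on a few compounds, and the source may have more. Where it says the series, first, only, none or still open, it means among the compounds named here.

Measured so far:
compound 1 `Cc1ccc2nc([C@H](CC(C)C)N3C(=O)CN(c4ccc(Oc5ccccc5)cc4)C3=O)n(C)c2c1` gives 65600 nM
compound 2 `CC(C)C[C@@H](c1nc2ccc(C(=O)O)cc2n1C)N1C(=O)CN(c2ccc(Oc3ccccc3)cc2)C1=O` gives 43400 nM

Both values come from an assay on isolated protein for inhibition of Bile acid receptor (Homo sapiens), read by TR-FRET and LanthaScreen; on this read-out lower numbers stand for stronger inhibition and higher numbers for weaker inhibition. Among the compounds with values here, compound 2 holds the lowest of the two numbers, but its only neighbour, compound 1, sits within the usual scatter of it. Within the data shown here, the single measured step, a 1.5-fold lower number from compound 1 to compound 2 (0.18 log units; within the scatter), accompanied carboxy in place of methyl on an aromatic carbon and tells nothing about a difference in potency.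

Compound 3 `CC(C)C[C@@H](c1nc2ccc(C(=O)O)cc2n1C)N1C(=O)CN(c2ccc(-c3ccccc3)cc2)C1=O` has not been measured. It differs from compound 2 by phenyl in place of phenoxy on an aromatic carbon. Among the measured compounds shown here, none of the measured steps touches that part of the molecule, so no measured step bears on this change, and there is no basis for expecting a shift beyond the scatter. The expected step is a 1.0-fold lower number from compound 2 to compound 3 (0.00 log units; within the scatter). Compound 3 is therefore estimated at 43000 nM, with a range from 14000 nM to 130000 nM.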

Compound 3, half-maximal inhibitory concentration: 23100 nM
Compound 3: the middle estimate sits 1.9-fold (0.27 log units) above what was measured; the range from low to high includes it.
By their numbers in this assay, from the lowest: compounds 3, 2 and 1 (each within the scatter of the next, the first and the last beyond it).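

Placing phenyl instead of phenoxy on this aromatic carbon, para to a large group, gives a 1.9-fold lower number from compound 2 to compound 3 (0.27 log units; within the scatter) in this assay. Within the data shown here, this is the first reading at this position, which the earlier step left untouched: losing the oxygen atom of phenoxy, and with it a hydrogen-bond acceptor, leaves the number within the scatter. The two groups cannot be told apart here, and nothing measured links the result to a property of either group.

As far as these compounds go, it remains open whether a different group here, such as cyclohexyl, methoxy or a chlorine atom, would move the number beyond the scatter. From the compounds shown here alone, it is also open whether phenyl would read the same with a methyl in place of the carboxy, as in compound 1.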